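Replacing a para substituent on the benzylidene ring

The source may report more compounds than this note shows. Statements on the series, on what has been measured and on what is new or still open speak of the compounds shown alone.

Measured compounds:
Compound 1, `COc1cc2c(Oc3ccc(NC(=O)N/N=C/c4ccc(C(F)(F)F)cc4)cc3F)ccnc2cc1OCCCN1CCCCC1`: 660 nM
Compound 2, `COc1cc2c(Oc3ccc(NC(=O)N/N=C/c4ccc(OC(F)(F)F)cc4)cc3F)ccnc2cc1OCCCN1CCCCC1`: 510 nM

In a functional assay on HT-29 cells (Homo sapiens) for cytotoxicity, read by MTT assay, with a stated time of 72 h (a higher number here means a weaker inhibitor, a lower number a stronger inhibitor), compound 2 gives the lower of the two numbers, but its neighbour compound 1 sits close by: the step of a 1.3-fold lower number from compound 1 to compound 2 (0.11 log units; within the scatter) is within the scatter, so the two cannot be ordered. Compound 3, `COc1cc2c(Oc3ccc(NC(=O)N/N=C/c4ccc(N(C)C)cc4)cc3F)ccnc2cc1OCCCN1CCCCC1`, has not yet been measured. It differs from compound 2 in one place: dimethylamino in place of trifluoromethoxy on an aromatic carbon. Going by the values given here, only one measured step exists, and it exchanges trifluoromethyl for trifluoromethoxy at the same aromatic carbon, a change that left the number essentially unchanged. Among the compounds with values here, no measured pair exchanges a fluorine-bearing group for dimethylamino, so nothing here tells how large a step to expect. The estimate for compound 3 therefore stays near compound 2, with a wide band; the expected step is a 1.2-fold higher number from compound 2 to compound 3 (0.07 log units; within the scatter), and compound 3 is estimated at 600 nM, in a range from 200 nM to 2000 nM.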

Compound 3, half-maximal inhibitory concentration: 1000 nM
Beside the measured number, compound 3's estimate is 1.7-fold (0.22 log units) below it, within the range that was stated.
By their numbers in this assay, from the lowest: compounds 2, 1 and 3 (each within the scatter of the next).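

Going by these compounds alone, with dimethylamino at this position, the first group without fluorine, the exchange in this assay gives a 2.0-fold higher number from compound 2 to compound 3 (0.29 log units; within the scatter), and set against trifluoromethyl it gives a 1.5-fold higher number from compound 1 to compound 3 (0.18 log units; within the scatter). This position on the ring therefore accepted a group with nitrogen bound to the ring in place of a fluorine-bearing group, with no step beyond the scatter, and the three compounds cannot be firmly ordered. Nothing in the available data bears on why the numbers fall as they do.

The compounds shown leave open whether a group of another kind at this position, such as a carboxylic acid or a longer alkoxy chain, would carry the number beyond the scatter. They also leave open whether a plain hydrogen on this carbon would set a compound apart from these three.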